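Cyano for hydroxymethyl on the triazole-bound phenyl ring

The compounds below may be only part of what the source reports. "The series", "measured", "known", "first", "only" and "open" are said of these compounds alone.

Among the compounds with values here, the two measured members share one core and differ only in the group on the phenyl ring attached to the triazole. In a functional assay on T47D cells (Homo sapiens) for cytotoxicity, read by MTT assay, with a stated time of 24 h (on this read-out lower numbers stand for stronger inhibition and higher numbers for weaker inhibition), compound 1 `COc1ccc(/C=C\C(=O)O)c(OCc2cn(-c3ccc(NC(C)=O)cc3)nn2)c1CC=C(C)C` gives 17400 nM, and compound 2 `COc1ccc(/C=C\C(=O)O)c(OCc2cn(-c3ccc(CO)cc3)nn2)c1CC=C(C)C` gives 40000 nM. Within the data shown here, that puts compound 2 at the highest of the two numbers recorded, the step of a 2.3-fold higher number from compound 1 to compound 2 (0.36 log units; beyond the scatter) being the only comparison available.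

Compound 3 `COc1ccc(/C=C\C(=O)O)c(OCc2cn(-c3ccc(C#N)cc3)nn2)c1CC=C(C)C` follows from compound 2 through a single change: cyano in place of hydroxymethyl on an aromatic carbon. Among the measured compounds shown here, no measured step involves a cyano group, so the only guide is the step from compound 1 to compound 2, which shows that exchanging the substituent at this place moves the number only modestly. A cyano group shares with hydroxymethyl the single acceptor but lacks the donor, so the expected effect is small and without a clear direction. The step from compound 2 to compound 3 is therefore estimated as a 1.4-fold lower number from compound 2 to compound 3 (0.15 log units; within the scatter), within or close to the scatter. Compound 3 is expected to give about 28000 nM, with a range from 10000 nM to 70000 nM.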

Compound 3, half-maximal inhibitory concentration: 10200 nM
Estimate against measurement, compound 3: 2.7-fold (0.44 log units) above; the range from low to high includes it.
By their numbers in this assay, from the lowest: compounds 3 and 1 (each within the scatter of the next); then compound 2.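

Replacing hydroxymethyl with cyano on the triazole-bound phenyl ring moves the number in this assay by more than the scatter (a 3.9-fold lower number from compound 2 to compound 3 (0.59 log units; beyond the scatter)), so this place responds to a change between two small groups of equal heavy-atom count. Cyano and acetamido cannot be separated in this assay (a 1.7-fold lower number from compound 1 to compound 3 (0.23 log units; within the scatter)), which leaves compound 2 as the weakest of the three, with its steps to compound 1 and compound 3 both printed as beyond the scatter; the earlier single step could not show that hydroxymethyl stands apart from two other groups at this place. No measurement of any property of these groups is at hand to account for the difference.

Within the data shown here, with only three groups at this place, it remains open whether an amine, a carboxylic acid or a chlorine atom would fall with compound 1 and compound 3 or with compound 2. As far as these compounds go, it is also open whether a longer chain ending in hydroxyl would give a number like that of compound 2.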